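This account rests on a few compounds, and the source may have more. Where it says the series, first, only, none or still open, it means among the compounds named here.

For the measured compounds named here, compound 2 `O=C(CCl)Nc1ccc(C(=O)/C=C/c2ccc(Cl)cc2)cc1` is the only compound here with a number: in a functional assay on MGC-803 cells (Homo sapiens) for cytotoxicity, read by MTT assay, with a stated time of 72 h (on this read-out higher numbers stand for weaker inhibition and lower numbers for stronger inhibition), compound 2 gives 4960 nM. Compound 1 `Cc1cccc(NC(=O)CSC(=S)N[C@H]2CCOC2=O)c1C` has "not determined" (no result reported) in this assay, so it offers no comparison. Compound 3 `O=C(CCl)Nc1ccc(C(=O)/C=C/c2ccc(Br)cc2)cc1` carries a single change from compound 2: bromo in place of chloro on an aromatic carbon. Going by the values given here, no step between measured compounds shows what such a swap does, so the change is expected to stay within the usual scatter, with no clear direction: a 1.1-fold lower number from compound 2 to compound 3 (0.04 log units; within the scatter). On that basis compound 3 is estimated at 4500 nM, with a range from 2000 nM to 11000 nM.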

Compound 3, half-maximal inhibitory concentration: 6050 nM
The estimate for compound 3 lay 1.3-fold (0.13 log units) below the measured number; the range from low to high includes it.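

In this assay, replacing 4-chlorophenyl with 4-bromophenyl gives a 1.2-fold higher number from compound 2 to compound 3 (0.09 log units; within the scatter) on this shared core. For the compounds shown here, this is the first measured step for this change, and it shows that chloro and bromo at this position cannot be told apart in this assay. Nothing shown here offers an explanation for this result.

Going by these compounds, it remains open whether a different kind of group at the same position, such as an amine or a carboxylic acid, would move the number beyond the usual scatter. It is also unknown whether the same swap would read alike on another core.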